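The source may report more compounds than this note shows. Statements on the series, on what has been measured and on what is new or still open speak of the compounds shown alone.

Measured so far in a functional assay on MCF7 cells (Homo sapiens) for inhibition, read by sulforhodamine B assay, with a stated time of 72 h; on this read-out lower numbers stand for stronger inhibition and higher numbers for weaker inhibition:
compound 1 `CC(c1ccc(-c2ccccc2)c(F)c1)c1nnc2n1N=C(c1ccc(OC(F)(F)F)cc1)CS2` gives 4800 nM
compound 2 `COc1ccc2cc(C(C)c3nnc4n3N=C(c3ccc(Cl)cc3Cl)CS4)ccc2c1` gives 14600 nM
compound 3 `CC(c1ccc(-c2ccccc2)c(F)c1)c1nnc2n1N=C(c1ccc(C(F)(F)F)cc1)CS2` gives 4300 nM

Compound 3 gives the lowest number of the three, though compound 1 lies within the scatter of it; only compound 2 lies beyond it, at the higher number. Compound 4 `CC(c1ccc(-c2ccccc2)c(F)c1)c1nnc2n1N=C(c1ccc(Cl)cc1Cl)CS2` differs from compound 3 in one place: 2,4-dichlorophenyl in place of 4-(trifluoromethyl)phenyl on a carbon with a double bond to nitrogen. For the measured compounds named here, the only measured step on the same ring is a 1.1-fold lower number from compound 1 to compound 3 (0.05 log units; within the scatter), a swap on that ring that left the number within the scatter. Going by the values given here, no measured step brings in the 2,4-dichlorophenyl; compound 2 carries it but differs from compound 3 in a second place as well, so its value shows only that this group gives a measurable number. A small rise or no step beyond the scatter is therefore expected, a 1.4-fold higher number from compound 3 to compound 4 (0.14 log units; within the scatter). Compound 4 is expected at 6000 nM, with a range from 2500 nM to 15000 nM.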

Compound 4, half-maximal inhibitory concentration: 7600 nM
Compound 4: middle estimate off by 1.3-fold (0.10 log units), on the low side, and the stated range covers the measured number.
By their numbers in this assay, from the lowest: compounds 3, 1, 4 and 2 (each within the scatter of the next, the first and the last beyond it).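

In this assay, the 2,4-dichlorophenyl can now be read directly against the two para-free comparisons in the series: a 1.8-fold higher number from compound 3 to compound 4 (0.25 log units; within the scatter) and a 1.6-fold higher number from compound 1 to compound 4 (0.20 log units; within the scatter). At this carbon with a double bond to nitrogen, 4-(trifluoromethyl)phenyl, 2,4-dichlorophenyl and the trifluoromethoxy-bearing ring therefore cannot be told apart, even with a second chlorine on the ring. No measurement at hand accounts for these numbers.

Open, on these data alone, is whether an amine or a carboxylic acid on this ring would move the number beyond the scatter. Also open, as far as these compounds go, is whether these swaps behave alike with another group on the other side of the shared core.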